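A Fluoro Group Added to the Benzyl Side Chain

The compounds below may be only part of what the source reports. "The series", "measured", "known", "first", "only" and "open" are said of these compounds alone.

Of the compounds shown here, two on a shared core have numbers so far. In an ADME assay on HEK293 cells (Homo sapiens) for cytotoxicity, read by MTT assay, with a stated time of 24 h (on this read-out higher numbers stand for weaker inhibition and lower numbers for stronger inhibition), compound 1 (`CN(C)CCCCNc1nc2cc([N+](=O)[O-])ccc2nc1NCc1ccc(C(F)(F)F)cc1`) gives 9.73 ug/mL as its result. Compound 2 (`CN(C)CCCNc1nc2cc([N+](=O)[O-])ccc2nc1NCc1ccccc1`) gives 2.74 ug/mL as the lower of the two numbers, and the gap between them lies beyond the usual scatter. For the measured compounds named here, no measured pair differs in one place only, so no measured step speaks directly to the change ahead.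

Compound 3 (`CN(C)CCCNc1nc2cc([N+](=O)[O-])ccc2nc1NCc1ccc(F)cc1`) departs from compound 2 at a single place: fluoro in place of hydrogen on an aromatic carbon in the benzylamino side chain, which becomes (4-fluorobenzyl)amino, with fluoro in place of hydrogen on an aromatic carbon, para to a large group. Going by the values given here, with no measured step to go on, no step beyond the scatter is expected in this assay for this change, and no direction is favoured. The expected change is a 1.1-fold higher number from compound 2 to compound 3 (0.04 log units; within the scatter) in this estimate. Compound 3 is estimated at 3 ug/mL with an expected range from 1.4 ug/mL to 6.5 ug/mL on the same read-out.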

Compound 3, half-maximal inhibitory concentration: 4.28 ug/mL
Beside the measured number, compound 3's estimate is 1.4-fold (0.15 log units) below it; measured number inside the range.
By their numbers in this assay, from the lowest: compounds 2 and 3 (each within the scatter of the next); then compound 1.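

For the compounds shown here, this is the first pair of measured compounds that differ in one place only, and it gives a direct reading for this position. In this assay, fluoro in place of hydrogen on an aromatic carbon, para to a large group, gives a 1.6-fold higher number from compound 2 to compound 3 (0.19 log units; within the scatter) and so does not separate compound 2 from compound 3 on this read-out; at this place in the benzylamino side chain, the change from benzyl to 4-fluorobenzyl leaves the number within the usual scatter of repeated measurements. No measured information is available to explain this result.

Going by these compounds, whether a chloro, methoxy or amino group at the same place would also stay within the scatter remains open. Compound 1 departs from compound 2 in more than one place, so the effect of a trifluoromethyl group alone at this place cannot be read from the compounds shown, and a longer chain on the otherwise unchanged compound 2 remains open as well.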